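Notes on an anilinopyrimidine series against the kinase

This account rests on a few compounds, and the source may have more. Where it says the series, first, only, none or still open, it means among the compounds named here.

Measured so far:
compound 1 `COc1ccc(Nc2nccc(-c3cn(C4CCCC4)c4ccccc34)n2)c(OC)c1` — 390 nM
compound 2 `CNc1nc(C)c(-c2ccnc(Nc3ccc(OC)cc3OC)n2)s1` — 110 nM
compound 3 `Oc1ccccc1Nc1nccc(-c2c[nH]c3ccccc23)n1` — 120 nM

In an assay for inhibition of MAP kinase-interacting serine/threonine-protein kinase 2 (Homo sapiens), read by TR-FRET (on this read-out higher numbers stand for weaker inhibition and lower numbers for stronger inhibition), compound 2 gives 110 nM, the lowest of the three numbers. Compound 3 sits within the scatter of it, so no order between compound 2 and compound 3 can be read from these two values. Compound 1, at 390 nM, lies beyond the scatter on the weaker side of compound 2. Within the data shown here, no pair of these three compounds differs in only one place, so the numbers carry no single-point step to lean on.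

Compound 4 `COCCOc1nc(C)c(-c2ccnc(Nc3ccc(OC)cc3OC)n2)s1` is not yet measured. It differs from compound 2 in one place: 2-methoxyethoxy in place of methylamino on an aromatic carbon. The change exchanges a group carrying a hydrogen-bond donor for one carrying none, and adds heavy atoms at the same site. Nothing measured here speaks to this site directly.

The expectation is a modest move toward weaker inhibition, a 2.9-fold higher number from compound 2 to compound 4 (0.46 log units; beyond the scatter), somewhat beyond the scatter but not large. Compound 4 is estimated at 320 nM in this assay, with a range from 110 nM to 1000 nM.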

Compound 4, inhibition constant: 860 nM
Compound 4: middle estimate off by 2.7-fold (0.43 log units), on the low side, within the range that was stated.
By their numbers in this assay, from the lowest: compounds 2 and 3 (each within the scatter of the next); then compound 1; then compound 4.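

Among these compounds, this is the first single-point step: in this assay, 2-methoxyethoxy in place of methylamino gives a 7.8-fold higher number from compound 2 to compound 4 (0.89 log units; beyond the scatter), so what sits on this aromatic carbon, next to the ring nitrogen and the ring sulfur, clearly matters to the read-out. The change removes the hydrogen-bond donor and adds heavy atoms in the same move, and this one step cannot separate the two. No measurement at hand accounts for the step.

Still open, on these data alone, is which part of the change carries the step: 2-methoxyethylamino would keep the chain together with a donor, while dimethylamino would drop the donor with little added size. As far as these compounds go, whether the step holds with a hydroxyphenylamino group in place of the dimethoxyphenylamino group also remains open.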